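Cytotoxicity notes: pyrazolopyrimidine series, compound 3 to compound 4

The compounds below may be only part of what the source reports. "The series", "measured", "known", "first", "only" and "open" are said of these compounds alone.

Compound 3 `OCCn1ncc2c(Nc3ccc(OC(F)(F)F)cc3)ncnc21` carries a 2-hydroxyethyl group on an aromatic nitrogen of the shared core; in an ADME assay on BaF3 cells (Mus musculus) for cytotoxicity (a lower number here means that less compound is needed, a higher number that more compound is needed for the effect), compound 3 gives only a limit, > 10000 nM. Compound 1 `FC(F)(F)Oc1ccc(Nc2ncnc3c2cnn3C2CCCCC2)cc1`, with cyclohexyl in that position, gives 9300 nM in this assay. The measured step of an at least 1.0-fold higher number from compound 1 to compound 3 (0.03 log units; that floor lies within the scatter) therefore sets only a floor, and compound 3 sits at the limit of > 10000 nM in this assay, at which 2 of the 3 values shown sit. Compound 2 `COC(=O)c1cc2c(Nc3ccc(OC(F)(F)F)cc3)ncnc2s1`, on a different core, likewise gives only a limit in this assay, > 10000 nM. Compound 4 `NC(=O)c1ccc(Cn2ncc3c(Nc4ccc(OC(F)(F)F)cc4)ncnc32)cc1` is not yet measured; the change from compound 3 is 4-carbamoylphenyl in place of hydroxymethyl on a saturated chain carbon bound to an aromatic nitrogen. Within the data shown here, no measured step covers a 4-carbamoylbenzyl group, so the expectation rests on compound 3 alone: the step that the limit leaves unreadable from compound 3 to compound 4 is expected to stay within the scatter. Compound 4 is therefore estimated at 12000 nM in this assay, with a range from 4000 nM to 40000 nM, and a limit is the likelier outcome.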

Compound 4, half-maximal effective concentration: > 10000 nM
Compound 4: a limit, no number; the forecaster's own chance of this, stated with the estimate: 60%; the middle value is on the limit's open side.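

In this assay compound 4 gives only a limit, > 10000 nM, so an aromatic ring in the group on the aromatic nitrogen brings no readable value. The step between compound 3 and compound 4 cannot be read, both values being limits, and an at least 1.0-fold higher number from compound 1 to compound 4 (0.03 log units; that floor lies within the scatter) sets only a floor that does not separate 4-carbamoylbenzyl from cyclohexyl. The values now gather at one point: the limit of > 10000 nM in this assay, at which 3 of the 4 values shown sit.

On these data alone, whether an amine or a carboxylic acid in place of the carbamoyl group would give a number under this limit stays open. The same holds for a longer chain between the aromatic nitrogen and the ring.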